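The source may report more compounds than this note shows. Statements on the series, on what has been measured and on what is new or still open speak of the compounds shown alone.

Working notes on a cyclopentenone series. Compound 1 `C=CCOc1cc(C2=C(c3cc(OC)c(OC)c(OC)c3)C(=O)C(O)C2)ccc1OC` carries a trimethoxyphenyl ring on one side of the shared core and an allyloxy-bearing methoxyphenyl ring on the other. In an ADME assay on DU-145 cells (Homo sapiens) for cytotoxicity, read by MTT assay, with a stated time of 72 h (a lower number here means a stronger inhibitor, a higher number a weaker inhibitor), compound 1 gives only a limit, > 100 ug/mL, not a number. Compound 2 `CCOC(=O)COc1ccc(C2=C(c3cc(OC)c(OC)c(OC)c3)C(=O)CC2O)cc1` likewise yields only a limit in this assay, > 100 ug/mL. Compound 3 `O/N=C1/CC(O)C(c2ccccc2)=C1c1ccccc1`, the oxime with two unsubstituted phenyl rings, also stops at a limit, > 100 ug/mL. For the measured compounds named here, compound 1 therefore stands nowhere that can be told apart from the rest: the limit of > 100 ug/mL in this assay, at which 3 of the 3 values shown sit, and no step between measured compounds can be read at all.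

The unmeasured compound 4 `COc1ccc(C2=C(c3cc(OC)c(OC)c(OC)c3)C(=O)C(O)C2)cc1F` differs from compound 1 in one place: fluoro in place of allyloxy on an aromatic carbon. The methoxy group and the trimethoxyphenyl ring remain as in compound 1.

Going by the values given here, with three limits and no measured step, the numbers give no basis for the size or direction of this change in this assay, and the expectation is that the change does not clearly carry compound 4 beyond the scatter. Compound 4 is expected near 50 ug/mL, within 5 ug/mL to 150 ug/mL, with a fair chance that this assay again reports only a limit. Among the compounds with values here, the step this estimate implies, an at least 2.0-fold lower number from compound 1 to compound 4 (0.30 log units; that floor lies within the scatter), is itself an expectation and rests on no measured step.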

Compound 4, half-maximal inhibitory concentration: 27 ug/mL
Beside the measured number, compound 4's estimate is 1.9-fold (0.27 log units) above it; the measured number falls inside the stated range.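

Compound 4 is the only compound shown that gives a number in this assay, 27 ug/mL. The other three compounds stop at a limit of the assay: the limit of > 100 ug/mL in this assay, at which 3 of the 4 values shown sit.

Going by these compounds, at this aromatic carbon, ortho to a methoxy group and meta to a large group, fluoro in place of allyloxy gives an at least 3.7-fold lower number from compound 1 to compound 4 (0.56 log units; beyond the scatter), so this position can move the read-out, although the full size of the step stays unknown while compound 1 has only a limit.

For the compounds shown here, the single pair cannot separate what the fluoro group adds from what the loss of allyloxy removes, and no step involving compound 2 or compound 3 can be read. A bare hydrogen, a chloro group, a hydroxyl group or an amine at this carbon, or a longer chain than allyloxy, would show whether the read-out follows the incoming group or simply the removal of allyloxy, and whether the step holds on other members of the series.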